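The source may hold more compounds than are shown below. What is called first, only, known or untested is meant among the compounds shown, and "the series" means these compounds.

Compound 3 `NC(=O)c1c(NC(=O)c2ccccc2Cl)sc2c1CCN(C(=S)Nc1ccccc1I)C2` holds the lowest number among the three compounds measured in a functional assay on MKN-74 cells (Homo sapiens) for antiproliferative activity, with a stated time of 24 h; a higher number here means a weaker inhibitor, a lower number a stronger inhibitor: compound 3 gives 2630 nM. Compound 1 `NC(=O)c1c(NC(=O)c2ccccc2Cl)sc2c1CCN(Cc1ccc(Cl)cc1)C2` gives 18700 nM, and compound 2 `NC(=O)c1c(NC(=O)c2ccccc2Cl)sc2c1CCN(C(=O)Nc1ccccc1Cl)C2` gives 16300 nM. Both steps ending in compound 3 lie beyond the scatter, a 7.1-fold lower number from compound 1 to compound 3 (0.85 log units; beyond the scatter) and a 6.2-fold lower number from compound 2 to compound 3 (0.79 log units; beyond the scatter), while the step of a 1.1-fold lower number from compound 1 to compound 2 (0.06 log units; within the scatter) lies within it. Compound 4 `NC(=O)c1c(NC(=O)c2ccccc2Cl)sc2c1CCN(C(=S)Nc1ccccc1-c1ccccc1)C2` differs from compound 3 in a single place: phenyl in place of iodo on an aromatic carbon. Neither measured step touches this place. Among the measured compounds shown here, the two steps ending in compound 3 exchange the whole group on the ring nitrogen, a 4-chlorobenzyl or a (2-chlorophenyl)carbamoyl giving way to the thiourea that bears the 2-iodophenyl, and no measured pair varies a substituent on that outer ring. The thiourea linkage that sets compound 3 apart is kept in compound 4. For the measured compounds named here, with no measured step on this point, the expected step of a 1.1-fold higher number from compound 3 to compound 4 (0.06 log units; within the scatter) is none beyond the scatter, carrying wide uncertainty. Because compound 3 gives 2630 nM with the same linkage, compound 4 is estimated at 3000 nM, within a range from 900 nM to 10000 nM.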

Compound 4, half-maximal inhibitory concentration: 25800 nM
The estimate for compound 4 lay 8.6-fold (0.93 log units) below the measured number; measured number outside the range, above it.
By their numbers in this assay, from the lowest: compound 3; then compounds 2, 1 and 4 (each within the scatter of the next).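

In this assay, the outer ring of the thiourea now has a measured step of its own: with the linkage kept, phenyl in place of iodo on an aromatic carbon, ortho to a large group, gives a 9.8-fold higher number from compound 3 to compound 4 (0.99 log units; beyond the scatter), a step beyond the scatter. The earlier steps shown here exchanged the whole group on the ring nitrogen, whereas this pair shows that the thiourea linkage alone does not secure the low number of compound 3, and that the group on this aromatic carbon matters as well. The change from 2-iodophenyl to 2-phenylphenyl adds a six-membered aromatic ring of carbon only, with no hydrogen-bond donors or acceptors and no net charge on either side, and nothing measured here explains the rise in the number.

Going by these compounds, it remains open how a methyl, a methoxy or a bare hydrogen on this aromatic carbon would compare with iodo and phenyl. Also open, on these data alone, is whether the same exchange would give a step of similar size on a urea linkage like that of compound 2.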